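Trifluoromethyl for Trifluoromethoxy: Microsomal Clearance Notes

The source may hold more compounds than are shown below. What is called first, only, known or untested is meant among the compounds shown, and "the series" means these compounds.

Compound 1 `Cc1nc2cc(OC(F)(F)F)ccc2n1-c1ccc(C(=O)NC2CC2)s1` and compound 2 `Cc1nc2ccc(OC(F)(F)F)cc2n1-c1ccc(C(=O)NC2CC2)s1` are built from the same atoms joined differently; the difference between the two cores is not broken down here. In an in vitro ADME assay on microsomes from liver (Mus musculus) for pharmacokinetics, read by LC-MS (on this read-out lower numbers stand for slow clearance and higher numbers for fast clearance), compound 1 gives 43 mL/min/kg. In this assay compound 2 gives 41 mL/min/kg, within the scatter of compound 1. Compound 3 `Cc1nc2cc(C(F)(F)F)ccc2n1-c1ccc(C(=O)NC2CC2)s1` carries the change trifluoromethyl in place of trifluoromethoxy on an aromatic carbon on the core of compound 1. In this assay compound 3 sits at > 72 mL/min/kg, a limit of the assay and not a number. The measured step is an at least 1.6-fold higher number from compound 1 to compound 3 (0.22 log units; that floor lies within the scatter), bounded by the limit of > 72 mL/min/kg in this assay, at which 1 of the 3 values shown sits. Compound 4 `Cc1nc2ccc(C(F)(F)F)cc2n1-c1ccc(C(=O)NC2CC2)s1` carries the same change on the core of compound 2, (trifluoromethyl in place of trifluoromethoxy on an aromatic carbon). In this assay the step is expected to be a 1.7-fold higher number from compound 2 to compound 4 (0.23 log units; within the scatter), resting on the measured step of an at least 1.6-fold higher number from compound 1 to compound 3 (0.22 log units; that floor lies within the scatter). Compound 4 is estimated at 70 mL/min/kg, between 45 mL/min/kg and 110 mL/min/kg.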

Compound 4, clearance: 68 mL/min/kg
Compound 4: the middle estimate sits 1.0-fold (0.01 log units) above what was measured; the measured number falls inside the stated range.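

In this assay, trifluoromethyl in place of trifluoromethoxy on the core of compound 2 gives a 1.7-fold higher number from compound 2 to compound 4 (0.22 log units; within the scatter), so this step alone shows no difference beyond the usual scatter. Both cores give steps of the same direction as printed, but that does not show that the change carries over with the same size: the same change on two cores in this assay, an at least 1.6-fold higher number (0.22 log units; that floor lies within the scatter) from compound 1 to compound 3 and a 1.7-fold higher number (0.22 log units; within the scatter) from compound 2 to compound 4; the limit leaves it open whether they differ. Compound 3 is the compound that stands at a limit of the assay, which is not a number: the limit of > 72 mL/min/kg in this assay, at which 1 of the 4 values shown sits.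

Left open is whether another group on the same aromatic carbon, such as a nitrile or an amine, would read differently in this assay. Also open, on these data alone, is how the change behaves on any core beyond these two.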